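A few compounds are considered here, and "the series" means these few. Any claim that something is new, unique, unknown or untested is made for them only; others in the source may bear on it.

Working notes on the series. The compounds share the core of compound 1 `COc1cc(N)c(Cl)cc1NC(=O)C1CCN(CC2CC2)CC1` and are varied only on a saturated chain carbon bound to an amine nitrogen in a ring; all are tested in a functional assay on the whole organism for antagonist activity, with Mus musculus as the target; a lower number here means that less compound is needed, a higher number that more compound is needed for the effect. Compound 1 returns only a limit of the assay, > 10 mg/kg. Compound 2 `COc1cc(N)c(Cl)cc1NC(=O)C1CCN(Cc2cccc(C#N)c2)CC1` likewise returns only a limit, > 4 mg/kg. Compound 3 `CCCCN1CCC(C(=O)Nc2cc(Cl)c(N)cc2OC)CC1` also stops at a limit, > 10 mg/kg. Compound 2 thus stands at a limit and not at a number; the three values are all limits, two of them at the limit of > 10 mg/kg in this assay, at which 2 of the 3 values shown sit, and one at the limit of > 4 mg/kg in this assay, at which 1 of the 3 values shown sits. The measured steps a step that the two limits leave unreadable from compound 1 to compound 2, a step that the two limits leave unreadable from compound 1 to compound 3 and a step that the two limits leave unreadable from compound 2 to compound 3 are accordingly unreadable in size and direction. Compound 4 `COc1cc(N)c(Cl)cc1NC(=O)C1CCN(Cc2ccc(O)cc2)CC1` differs from compound 2 by 4-hydroxyphenyl in place of 3-cyanophenyl on a saturated chain carbon bound to an amine nitrogen in a ring. Since a step that the two limits leave unreadable from compound 1 to compound 2, a step that the two limits leave unreadable from compound 1 to compound 3 and a step that the two limits leave unreadable from compound 2 to compound 3 give no readable size, the step that the limit leaves unreadable from compound 2 to compound 4 is expected to be no larger than the scatter. Compound 4 is therefore estimated at 10 mg/kg, with a range from 3 mg/kg to 30 mg/kg, and this assay may well again return only a limit.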

Compound 4, dose for half-maximal effect: > 8 mg/kg
Compound 4: only a limit was reported; the forecaster's own chance of this, stated with the estimate: 70%; the middle value lies beyond the limit too.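

In this assay compound 4 returns only a limit, > 8 mg/kg. Its steps to compound 1, compound 2 and compound 3 therefore cannot be read in size or direction. The compounds shown leave open how the four compare in this assay, and what dose any of them needs for the effect.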